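The source may report more compounds than this note shows. Statements on the series, on what has been measured and on what is new or still open speak of the compounds shown alone.

Measured compounds:
Compound 1, `Cc1cc(=O)oc2cc(Oc3no[n+]([O-])c3S(=O)(=O)c3ccccc3)ccc12`. In a functional assay on A2780/CDDP cells (Homo sapiens) for antiproliferative activity, read by MTT assay, with a stated time of 48 h (on this read-out lower numbers stand for stronger inhibition and higher numbers for weaker inhibition), compound 1 gives > 3150 nM, which is a limit of the assay rather than a number.
Compound 2, `O=C(COc1ccc2ccc(=O)oc2c1)OCCOc1no[n+]([O-])c1S(=O)(=O)c1ccccc1`. In this assay compound 2 gives > 20000 nM, again a limit and not a number.

Compound 2 stands, on the numbers shown, only as a limit; the one further value shown, that of compound 1, is also a limit, so no ordering of the two can be drawn from these values.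

Compound 3, `Cc1cc(=O)oc2cc(OCC(=O)OCCOc3no[n+]([O-])c3S(=O)(=O)c3ccccc3)ccc12`, has not yet been measured in this assay. It differs from compound 2 in one place: methyl in place of hydrogen on an aromatic carbon. For the measured compounds named here, no step between measured compounds is available, so no measured step can guide the size of what is expected here. The change is small, and in this assay the step from compound 2 to compound 3 is expected to be none beyond the scatter, a step that the limit leaves unreadable from compound 2 to compound 3. Compound 3 is accordingly expected to come out near 25000 nM, within a range from 8000 nM to 80000 nM, with a high chance that only a limit is reported again.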

Compound 3, half-maximal inhibitory concentration: 7360 nM
Estimate against measurement, compound 3: 3.4-fold (0.53 log units) above; measured number below the stated range.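

In this assay, for the compounds shown here, methyl in place of hydrogen on an aromatic carbon, opposite the ring oxygen, gives an at least 2.7-fold lower number from compound 2 to compound 3 (0.43 log units; beyond the scatter), the first change that can be read as a step. With everything else in compound 2 left as it is, this position is therefore not silent: one added carbon is enough to move the read-out beyond the scatter, and compound 3 is the first compound shown that gives a number rather than a limit. Compound 2 stands only as a limit, so the step is a lower bound on the true size of the change: the limit of > 20000 nM in this assay, at which 1 of the 3 values shown sits.

As far as these compounds go, whether the shift belongs to methyl alone or would carry over to another group at this place, such as ethyl, an amine or a carboxylic acid, stays open, since a single step gives no trend. Compound 1 gives > 3150 nM, which is a limit, and it differs from compound 3 in more than one place, so the contribution of the ester chain cannot be read from these values.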